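The source may report more compounds than this note shows. Statements on the series, on what has been measured and on what is new or still open speak of the compounds shown alone.

Measured in a functional assay on EC9706 cells (Homo sapiens) for antiproliferative activity, read by MTT assay, with a stated time of 72 h; on this read-out higher numbers stand for weaker inhibition and lower numbers for stronger inhibition:
- Compound 1 `O=C(N/N=C/c1ccco1)c1cccc(S(=O)(=O)N2CCOCC2)c1`: > 100000 nM, a limit of the assay
- Compound 2 `COc1ccc(/C=N/NC(=O)c2cccc(S(=O)(=O)N3CCOCC3)c2)c(O)c1`: 1090 nM
- Compound 3 `O=C(N/N=C/c1cc(Cl)ccc1O)c1cccc(S(=O)(=O)N2CCOCC2)c1`: 2150 nM

Compound 3, at 2150 nM, stands within the scatter of compound 2, at 1090 nM. For the measured compounds named here, these are the only two actual numbers in the set, since the entry for compound 1 is a limit.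

In compound 4 `O=C(N/N=C/c1cc(Br)cc(Br)c1O)c1cccc(S(=O)(=O)N2CCOCC2)c1`, 3,5-dibromo-2-hydroxyphenyl takes the place of 5-chloro-2-hydroxyphenyl on a carbon with a double bond to nitrogen: 3,5-dibromo-2-hydroxyphenyl in place of 5-chloro-2-hydroxyphenyl on a carbon with a double bond to nitrogen.

Going by the values given here, three measured steps touch this same place. Two of them are large, an at least 91-fold lower number from compound 1 to compound 2 (1.96 log units; beyond the scatter) and an at least 46-fold lower number from compound 1 to compound 3 (1.66 log units; beyond the scatter), but both start from the furan-2-yl group, which plays no part in the change to compound 4. The closer guide is the exchange of one substituted hydroxyphenyl group for another, a 2.0-fold higher number from compound 2 to compound 3 (0.30 log units; within the scatter). Among the compounds with values here, it is a single step, so it gives only limited support, and no measured compound carries bromine.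

No step beyond the scatter is therefore expected in this assay, and neither direction is favoured with any confidence. The expected change is a 1.2-fold lower number from compound 3 to compound 4 (0.08 log units; within the scatter). For compound 4 the estimated value is 1800 nM, with an expected range of 500 nM to 7000 nM.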

Compound 4, half-maximal inhibitory concentration: 2440 nM
Compound 4: the middle estimate sits 1.4-fold (0.13 log units) below what was measured; low and high end bracket the measured number.
By their numbers in this assay, from the lowest: compounds 2, 3 and 4 (each within the scatter of the next, the first and the last beyond it). At a limit, above all of these: compound 1.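

In this assay, for the compounds shown here, the exchange of 5-chloro-2-hydroxyphenyl for 3,5-dibromo-2-hydroxyphenyl, which carries bromine for the first time in this set and one more heavy atom, gives a 1.1-fold higher number from compound 3 to compound 4 (0.05 log units; within the scatter), so this position accepts that larger halogen-bearing group with no change that can be told from the scatter. Among the hydroxyphenyl compounds, the first gap beyond the scatter now appears, a 2.2-fold higher number from compound 2 to compound 4 (0.35 log units; beyond the scatter), yet it is modest, and compound 3 lies within the scatter of both compounds, so the three form a continuous run and not two separate levels. The large step away from furan-2-yl also holds for a third hydroxyphenyl group, an at least 40-fold lower number from compound 1 to compound 4 (1.61 log units; beyond the scatter), and its size is only a bound, since the entry for compound 1 is a limit: the limit of > 100000 nM in this assay, at which 1 of the 4 values shown sits.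

The compounds shown leave open whether the hydroxyl itself matters, which a plain phenyl or a methoxy group in its place would test. They also do not separate the effect of bromine from that of a second halogen, nor show how a single bromine, a fluorine or an amine on this ring would read.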